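Furan-2-yl to Thiophen-2-yl on the Carbonyl Carbon

This account rests on a few compounds, and the source may have more. Where it says the series, first, only, none or still open, it means among the compounds named here.

Three compounds share one core and differ only in the group on the carbonyl carbon. Compound 1 `Cc1ccc(C(=O)NC(=N)NCCCCc2ccccc2)cc1` carries 4-methylphenyl there, and in an assay on CHO cells for inhibition of sodium channel protein type 2 subunit alpha (Homo sapiens) (on this read-out lower numbers stand for stronger inhibition and higher numbers for weaker inhibition), compound 1 gives 1140 nM. Compound 2 `N=C(NCCCCc1ccccc1)NC(=O)c1ccc(Cl)c(Cl)c1` carries 3,4-dichlorophenyl and in this assay compound 2 gives 7110 nM. Compound 3 `N=C(NCCCCc1ccccc1)NC(=O)c1ccco1` carries furan-2-yl and in this assay compound 3 gives 13800 nM. Compound 3 therefore stands at the highest of the three numbers, though its gap to compound 2, a 1.9-fold higher number from compound 2 to compound 3 (0.29 log units; within the scatter), is within the scatter, while its gap to compound 1, a 12-fold higher number from compound 1 to compound 3 (1.08 log units; beyond the scatter), is beyond it. Between the two phenyl-bearing compounds the step is a 6.2-fold higher number from compound 1 to compound 2 (0.79 log units; beyond the scatter).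

Compound 4 `N=C(NCCCCc1ccccc1)NC(=O)c1cccs1` takes one further step from compound 3: thiophen-2-yl in place of furan-2-yl on a carbonyl carbon. Among the measured compounds shown here, no measured step exchanges one five-membered ring for another. The two steps that end at compound 3 both replace a six-membered ring by furan-2-yl, one within the scatter and one beyond it, so they bear only loosely on this change. For compound 4 the expected step is a 1.6-fold lower number from compound 3 to compound 4 (0.21 log units; within the scatter), at most a small move toward a lower number. Compound 4 is accordingly estimated at 8500 nM, with a range from 3000 nM to 25000 nM.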

Compound 4, half-maximal inhibitory concentration: 4310 nM
The estimate for compound 4 lay 2.0-fold (0.29 log units) above the measured number; measured number inside the range.
By their numbers in this assay, from the lowest: compound 1; then compounds 4, 2 and 3 (each within the scatter of the next, the first and the last beyond it).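

Among the compounds shown here, exchanging one five-membered ring for another, with sulfur in place of oxygen and the heavy-atom count unchanged, is enough to shift the number at this carbonyl carbon in this assay: the change gives a 3.2-fold lower number from compound 3 to compound 4 (0.51 log units; beyond the scatter) and so shows that this position responds to the ring hetero atom alone, which the earlier steps, each replacing a six-membered ring, could not separate. Thiophen-2-yl still falls short of 4-methylphenyl, with a 3.8-fold higher number from compound 1 to compound 4 (0.58 log units; beyond the scatter) setting it apart, whereas thiophen-2-yl and 3,4-dichlorophenyl cannot be told apart, at a 1.6-fold lower number from compound 2 to compound 4 (0.22 log units; within the scatter) for that exchange, so a five-membered ring as such does not fix the number in this small set. Nothing available explains why the two five-membered rings differ.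

The compounds shown leave open whether a methyl group or a chlorine on the thiophen-2-yl ring would bring the number closer to that of compound 1, and whether a saturated ring such as cyclohexyl would be tolerated on the carbonyl carbon. They also leave open how a shorter or longer chain on the far side of the shared core would act alongside thiophen-2-yl.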